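Bromo for nitro on the pendant phenyl ring

The compounds below may be only part of what the source reports. "The series", "measured", "known", "first", "only" and "open" are said of these compounds alone.

Measured compounds in this series:
- compound 1 `COc1ccc(-c2nc3sc(Cc4ccccc4)nn3c2SC#N)cc1`, 4100 nM
- compound 2 `O=Cc1c(-c2ccc([N+](=O)[O-])cc2)nc2sc(Cc3ccccc3)nn12`, 3100 nM
- compound 3 `O=[N+]([O-])c1ccc(-c2nc3sc(Cc4ccccc4)nn3c2Br)cc1`, 52500 nM

All three were tested in a functional assay on cells (Cancer cell lines, Homo sapiens) for inhibition; a higher number here means a weaker inhibitor of growth, a lower number a stronger inhibitor of growth. Compound 2 gives the lowest number of the three; compound 1 sits nearest to it, within the scatter, while compound 3 lies furthest away, beyond the scatter. Going by the values given here, the one step between two compounds that differ in a single place is a 17-fold higher number from compound 2 to compound 3 (1.23 log units; beyond the scatter), and that change sits on the shared core rather than on the phenyl ring.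

Compound 4 `O=Cc1c(-c2ccc(Br)cc2)nc2sc(Cc3ccccc3)nn12` is not yet measured. It differs from compound 2 as follows: bromo in place of nitro on an aromatic carbon. Among the compounds with values here, no measured step alters this ring position, so the measured step from compound 2 to compound 3 bears on it only by showing that a bromo substituent is tolerated somewhere. Compound 1 and compound 2 carry different groups on the phenyl ring yet fall within the scatter of each other, which suggests that a change at this site need not move the number much.

For compound 4 the expected value in this assay is 4000 nM, with a range from 1500 nM to 15000 nM. The step this implies, a 1.3-fold higher number from compound 2 to compound 4 (0.11 log units; within the scatter), is expected to stay close to the scatter.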

Compound 4, concentration for 50% growth inhibition: 2200 nM
Compound 4: the middle estimate sits 1.8-fold (0.26 log units) above what was measured; the measured number falls inside the stated range.
By their numbers in this assay, from the lowest: compounds 4, 2 and 1 (each within the scatter of the next); then compound 3.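

In this assay, going by these compounds alone, this is the first step that changes the group on the phenyl ring alone, and a 1.4-fold lower number from compound 2 to compound 4 (0.15 log units; within the scatter) shows that bromo can replace nitro at this place, para to a large group, without a readable change in the number. The replacement removes nitro and its hydrogen-bond acceptors and brings in bromo, which has none, yet compound 4 remains within the scatter of compound 2, so the number in this pair does not depend on those acceptors. Set against a 17-fold higher number from compound 2 to compound 3 (1.23 log units; beyond the scatter), where bromo replaces formyl on the shared core, the result shows that the outcome of introducing bromo in this series depends on where it sits, although no measurement on hand explains why nitro and bromo read alike on the phenyl ring.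

On these data alone, only nitro and bromo can be compared directly at this place, so it remains open whether an amine or a carboxylic acid there would also stay within the scatter of compound 2. Compound 1 differs from compound 2 in more than one place, so the contribution of its ring substituent alone cannot be read from its number.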